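Replacing the cyclohexylphenyl tail of a fatty acid receptor agonist

The source may report more compounds than this note shows. Statements on the series, on what has been measured and on what is new or still open speak of the compounds shown alone.

Two compounds share a core and a set of measurements in an assay on isolated protein for agonist activity at Free fatty acid receptor 1 (Homo sapiens); on this read-out lower numbers stand for an effect already at smaller amounts and higher numbers for an effect only at larger amounts of compound. Compound 1 `CC#CC(CC(=O)O)c1ccc(OCc2ccn3cc(-c4ccc(C5CCCCC5)cc4)nc3c2)cc1` gives 559 nM in this assay, which is the highest of the two numbers available. Compound 2 `CC#CC(CC(=O)O)c1ccc(OCc2ccc3nc(-c4ccc(C(C)C)cc4)cn3c2)cc1` gives 528 nM in this assay, and the two values lie within the scatter of each other, so nothing separates compound 1 from compound 2 on this read-out.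

Compound 3 `CC#CC(CC(=O)O)c1ccc(OCc2ccn3cc(-c4ccccc4C)nc3c2)cc1` has not yet been measured in this assay. It differs from compound 1 in one place: 2-methylphenyl in place of 4-cyclohexylphenyl on an aromatic carbon. Going by the values given here, no step between measured compounds corresponds to this change, so nothing in the data quantifies the effect of removing the cyclohexyl-bearing ring and moving to a smaller methyl-bearing ring on that aromatic carbon.

His expectation for compound 3 is a step to a higher number, beyond the scatter, given as a 4.5-fold higher number from compound 1 to compound 3 (0.65 log units; beyond the scatter), though with wide uncertainty. He estimates that compound 3 will give 2500 nM in this assay, with a range from 700 nM to 10000 nM.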

Compound 3, half-maximal effective concentration: 459 nM
For compound 3 the middle estimate is 5.4-fold (0.74 log units) above the measured one; measured number outside the range, below it.
By their numbers in this assay, from the lowest: compounds 3, 2 and 1 (each within the scatter of the next).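

In this assay, putting 2-methylphenyl in place of 4-cyclohexylphenyl on this aromatic carbon of the five-membered ring gives a 1.2-fold lower number from compound 1 to compound 3 (0.09 log units; within the scatter). At this position, then, a group of 12 heavy atoms with a non-aromatic carbon ring and a group of 7 heavy atoms with only an aromatic ring cannot be told apart on this read-out, so for this core the cyclohexyl ring is not required to keep the number within the scatter of compound 1, something compounds 1 and 2 alone could not show. Nothing available accounts for this tolerance of the position.

Going by these compounds alone, the single step removes the cyclohexyl ring and introduces a methyl at a different place on the phenyl ring together, so the compounds leave open what each of the two changes contributes alone, which an unsubstituted phenyl or a 4-methylphenyl at this carbon could begin to separate. They also leave open whether the position tolerates more than carbon-only groups, for instance a phenyl ring bearing an amine or a carboxylic acid.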